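The compounds below may be only part of what the source reports. "The series", "measured", "known", "first", "only" and "open" are said of these compounds alone.

Working notes on the series. Compound 1 `Nc1ncnc2c1ncn2[C@@H]1O[C@@]2(CO)CO[C@@H]1[C@@H]2O`, compound 2 `CNC(=O)[C@@]12CO[C@@H]([C@H](n3cnc4c(NCc5cccc(I)c5)ncnc43)O1)[C@@H]2O` and compound 3 `CNC(=O)[C@@]12CN[C@@H]([C@H](n3cnc4c(N)ncnc43)O1)[C@@H]2O` have been run so far. In a functional assay for antagonist activity at adenosine receptor A3 (Homo sapiens), with a stated time of 30 min (a higher number here means a weaker inhibitor, a lower number a stronger inhibitor), compound 1 gives > 100000 nM, which is a limit of the assay rather than a number. Compound 2 likewise gives only > 100000 nM in this assay, again a limit. Among the measured compounds shown here, compound 3 gives 170 nM in this assay, and this is the only number in the set. For the measured compounds named here, the remaining two entries sit at the limit of > 100000 nM in this assay, at which 2 of the 3 values shown sit, so compound 3 stands alone as the single measured value. Compound 4 `CNC(=O)[C@@]12CN[C@@H]([C@H](n3cnc4c(NCc5cccc(I)c5)ncnc43)O1)[C@@H]2O` is compound 3 with 3-iodobenzyl in place of hydrogen on a nitrogen on an aromatic ring. The same 3-iodobenzyl group is already present in compound 2, but compound 1 and compound 2 both stand at a limit, so that pair shows nothing about what the group does to the read-out. Going by the values given here, no step between measured compounds is available to size the change from compound 3. The expected step from compound 3 to compound 4 is a 1.5-fold higher number from compound 3 to compound 4 (0.17 log units; within the scatter), with no firm direction and quite possibly nothing beyond the usual scatter. Compound 4 is therefore estimated at 250 nM in this assay, within a range from 30 nM to 3000 nM, the width reflecting the absence of any measured step in the set.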

Compound 4, half-maximal inhibitory concentration: 12 nM
For compound 4 the middle estimate is 21-fold (1.32 log units) above the measured one; the whole stated range lies above it.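

In this assay, among the compounds shown here, the change now has a first measured size: a 14-fold lower number from compound 3 to compound 4 (1.15 log units; beyond the scatter), so 3-iodobenzyl on a nitrogen on an aromatic ring is not merely accepted on the core of compound 3 but goes with a clearly stronger inhibitor, which the earlier compounds could not show. Compound 2 carries the same 3-iodobenzyl group and gives > 100000 nM, which is a limit of the assay and not a number. The group therefore does not bring a measured value with it on every core shown, its step can be read on the core of compound 3 only, and the limit remains as common in the set as measured numbers: the limit of > 100000 nM in this assay, at which 2 of the 4 values shown sit.

The compounds shown do not separate the contribution of the iodine from that of the benzyl ring, which plain benzyl, 3-chlorobenzyl or a short chain such as methyl on the same nitrogen would address. Also open, from the compounds shown here alone, is whether the methylamide carbonyl group shared by compound 3 and compound 4 matters to the read-out, for which an ethylamide or a primary amide on the same core would be the comparison.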